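Dropping the Methoxy Group: From Compound 2 to Compound 3

This account rests on a few compounds, and the source may have more. Where it says the series, first, only, none or still open, it means among the compounds named here.

Of the compounds shown here, two built on a shared core have been measured in a functional assay on the whole organism (Ear, strain Kunming) for inhibition, with Mus musculus as the target, with a stated time of 2 h, at a dose of 200 mg/kg by the oral route; a higher number here means more inhibition at the dose given (going by the name of the read-out), a lower number less inhibition. Compound 1 `CN(C)c1ccc(/C=C/C(=O)c2ccc(O)cc2)cc1` is one of them, and in this assay compound 1 gives 17.3%. Compound 2 `COc1cc(/C=C/C(=O)c2ccc(O)cc2)ccc1O` is the other, and in this assay compound 2 gives 7.83%. This is the lower of the two numbers, but compound 1 stands only a little above it, and the two values lie within the scatter of each other, so no order can be read between them.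

Compound 3 `O=C(/C=C/c1ccc(O)cc1)c1ccc(O)cc1` has not yet been measured in this assay. It differs from compound 2 in one place: hydrogen in place of methoxy on an aromatic carbon. Within the data shown here, no step between measured compounds is available to gauge this change. Both measured values are low, and the one gap between them lies within the scatter. The step of a number 2.2 percentage points higher from compound 2 to compound 3 (within the scatter) is therefore expected to be small, in no clear direction, and within the scatter. In this assay compound 3 is expected to give about 10%, with a range from 0% to 25%.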

Compound 3, a percentage reported as inhibition, in the whole organism at one dose (the size of the read-out at that dose, not a potency): 5.42%
For compound 3 the middle estimate is 4.6 percentage points above the measured one, and the stated range covers the measured number.
By their numbers in this assay, from the lowest: compounds 3, 2 and 1 (each within the scatter of the next, the first and the last beyond it).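

In this assay, hydrogen in place of methoxy on an aromatic carbon, ortho to a hydroxy group, gives a number 2.4 percentage points lower from compound 2 to compound 3 (within the scatter), so this first step at this position shows no readable effect of the methoxy group on inhibition at the dose given. Compound 3 also provides the first gap beyond the scatter: hydroxy in place of dimethylamino on an aromatic carbon gives a number 11.9 percentage points lower from compound 1 to compound 3 (beyond the scatter), a modest step at a different place from the methoxy change, and the pair of compound 1 and compound 3 is the only one of the three that can be ordered. Nothing available explains either step, and no measurement bears on why the numbers stand as they do.

On these data alone, whether an amine or a carboxylic acid on the same aromatic carbon, or an ethoxy group in place of methoxy, would move the number beyond the scatter remains open. Also open, as far as these compounds go, is whether the gap between compound 1 and compound 3 would hold at other doses or with the dimethylamino group on a core that also carries methoxy, since all three numbers are low and each comes from one dose.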